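Nitrophenyl for cyclohexyl on the alkenyl side chain

The compounds below may be only part of what the source reports. "The series", "measured", "known", "first", "only" and "open" are said of these compounds alone.

Measured compounds:
compound 1 `O[C@@H](c1ccccc1)[C@H]1CO[C@H](c2ccccc2)[C@@H](C/C=C/C2CCCCC2)C1` — 6260 nM
compound 2 `COc1ccc(/C=C/C[C@H]2C[C@H]([C@H](O)c3ccc(OC)c(OC)c3)CO[C@@H]2c2ccc(OC)c(OC)c2)cc1OC` — 23500 nM

Both numbers come from a functional assay on HL-60 cells (Homo sapiens) for cytotoxicity, read by WST assay, with a stated time of 48 h; a lower number here means a stronger inhibitor, a higher number a weaker inhibitor. Compound 1 holds the lowest of the two numbers; compound 2 gives 23500 nM, a higher number than compound 1 by a gap that is beyond the scatter. The two compounds differ in more than one place, so the gap is noted only as what the two values show and is not assigned to any single change.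

Compound 3 `O=[N+]([O-])c1cccc(/C=C/C[C@H]2C[C@@H]([C@@H](O)c3ccccc3)CO[C@@H]2c2ccccc2)c1` is not yet measured in this assay. It differs from compound 1 in one place: 3-nitrophenyl in place of cyclohexyl on a double-bonded chain carbon bound to a double-bonded chain carbon. Among the compounds with values here, no step between measured compounds covers this change, so there is no direct precedent for its size or direction. Compound 1 is the only anchor, with 6260 nM. The step from compound 1 to compound 3 in this assay is expected to be modest, most likely a somewhat lower number, and it may also fall within the scatter; the expected step is a 1.6-fold lower number from compound 1 to compound 3 (0.19 log units; within the scatter). Compound 3 is therefore estimated at 4000 nM, with a range from 1200 nM to 14000 nM.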

Compound 3, half-maximal inhibitory concentration: 6350 nM
For compound 3 the middle estimate is 1.6-fold (0.20 log units) below the measured one, and the stated range covers the measured number.
By their numbers in this assay, from the lowest: compounds 1 and 3 (each within the scatter of the next); then compound 2.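

In this assay, within the data shown here, the position on a double-bonded chain carbon bound to a double-bonded chain carbon now has its first comparison in which only one place changes. Replacing cyclohexyl with 3-nitrophenyl gives a 1.0-fold higher number from compound 1 to compound 3 (0.01 log units; within the scatter), so this pair does not separate the two groups, even though the change swaps a non-aromatic ring of carbon only for an aromatic one and brings in hydrogen-bond acceptors. No measurement shown here offers a reason why the two values fall within the scatter of each other.

This single pair cannot show whether the position is generally insensitive to the group placed there or whether these two groups merely happen to give matching values, so unsubstituted phenyl, 3-aminophenyl and a phenyl ring carrying a carboxylic acid would be informative next comparisons. It also leaves open whether the same exchange would give a similar step on a core with different aryl groups, such as that of compound 2, where the side chain carries its own methoxy-substituted ring.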